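Three-to-four step: trifluoromethyl for methyl on the core

The source may report more compounds than this note shows. Statements on the series, on what has been measured and on what is new or still open speak of the compounds shown alone.

Measured compounds in a functional assay on LNCaP cells (Homo sapiens) for cytotoxicity, read by MTT assay; on this read-out higher numbers stand for weaker inhibition and lower numbers for stronger inhibition:
- compound 1 `c1ccc(-c2nnc(-c3c[nH]c4ccccc34)o2)cc1`: > 1000000 nM
- compound 2 `c1cncc(-c2nnc(-c3c[nH]c4ccccc34)o2)c1`: 69400 nM
- compound 3 `Cc1nnc(-c2c[nH]c3ccccc23)o1`: > 1000000 nM

Compound 3 gives only a limit of the assay in this assay, > 1000000 nM. Compound 1 likewise gives only a limit, > 1000000 nM. Within the data shown here, the one numerical value in the set belongs to compound 2, at 69400 nM. The two limits sit at the limit of > 1000000 nM in this assay, at which 2 of the 3 values shown sit, so the step that the two limits leave unreadable from compound 1 to compound 3 cannot be read, whereas the step of an at least 14-fold higher number from compound 2 to compound 3 (1.15 log units; beyond the scatter) is readable in size and direction.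

Compound 4 `FC(F)(F)c1nnc(-c2c[nH]c3ccccc23)o1` is not yet measured. Its change from compound 3 is trifluoromethyl in place of methyl on an aromatic carbon. Among the measured compounds shown here, none of the measured steps exchanges methyl for trifluoromethyl, and both steps that reach compound 3 come from aromatic replacements, so they bear on the new step only by placing compound 3 at the limit. No step beyond the scatter is expected; compound 4 is estimated to remain near the limit, at 800000 nM (range 150000 nM to 5000000 nM), which would mean a step of an at least 1.2-fold lower number from compound 3 to compound 4 (0.09 log units; that floor lies within the scatter).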

Compound 4, half-maximal inhibitory concentration: > 1000000 nM
Compound 4 was reported as a limit; the forecaster's own chance of this, stated with the estimate: 60%; middle value at least 1.2-fold (0.09 log units) away from the limit.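

In this assay compound 4 gives only a limit, so the steps among compound 1, compound 3 and compound 4 cannot be read, and all three stay at the same ceiling: the limit of > 1000000 nM in this assay, at which 3 of the 4 values shown sit.

Trifluoromethyl on this aromatic carbon therefore does not bring the series into the measurable range any more than methyl does. Exchanging pyridin-3-yl for trifluoromethyl gives an at least 14-fold higher number from compound 2 to compound 4 (1.15 log units; beyond the scatter), so this is a second group without a ring, after methyl, that falls well short of pyridin-3-yl, and among the four groups shown only pyridin-3-yl gives a numerical value.

On these data alone, how compound 1, compound 3 and compound 4 rank among themselves stays open. As far as these compounds go, it also stays open whether an amine, a carboxylic acid or a longer chain on this carbon would give a numerical value, as pyridin-3-yl does.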